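Replacing acetoxy with pyridinylsulfanyl on the shared core

The compounds below may be only part of what the source reports. "The series", "measured", "known", "first", "only" and "open" are said of these compounds alone.

Measured so far, in a physicochemical assay, at pH 7.4; on this read-out higher numbers stand for a longer-lived compound and lower numbers for a shorter-lived compound:
- compound 1, `CO[C@H]1C(=O)N2C(C(=O)C(C)(C)C)=C(C)CS(=O)(=O)C12`, gives 106 h
- compound 2, `CO[C@H]1C(=O)N2C(C(=O)C(C)(C)C)=C(C)[C@@H](Sc3nc(=O)c(=O)[nH]n3C)S(=O)(=O)C12`, gives 21 h
- compound 3, `CO[C@H]1C(=O)N2C(C(=O)C(C)(C)C)=C(C)[C@@H](OC(C)=O)S(=O)(=O)C12`, gives 6.3 h

Compound 3 stands lowest of the three in this assay; compound 2 is nearest, a step of a 3.3-fold lower number from compound 2 to compound 3 (0.52 log units; beyond the scatter) away, and compound 1 is furthest, a step of a 17-fold lower number from compound 1 to compound 3 (1.23 log units; beyond the scatter) away. Compound 4, `CO[C@H]1C(=O)N2C(C(=O)C(C)(C)C)=C(C)[C@@H](Sc3ccccn3)S(=O)(=O)C12`, is the next compound and has not yet been measured. It differs from compound 3 in one place: (pyridin-2-yl)sulfanyl in place of acetoxy on a saturated ring carbon.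

The most telling measured step runs the other way, a 3.3-fold lower number from compound 2 to compound 3 (0.52 log units; beyond the scatter), where a six-membered aromatic group joined through sulfur gave way to acetoxy. The steps of a 5.0-fold lower number from compound 1 to compound 2 (0.70 log units; beyond the scatter) and a 17-fold lower number from compound 1 to compound 3 (1.23 log units; beyond the scatter) show that both substituents shorten the half-life relative to the unsubstituted compound 1, with acetoxy doing so more. Since compound 4 again carries a sulfur-linked six-membered aromatic ring, the number is expected to move back toward that of compound 2, a modest rise of about a 3.5-fold higher number from compound 3 to compound 4 (0.54 log units; beyond the scatter) in this assay. Compound 4 is therefore estimated at 22 h, within a range of 9 h to 55 h.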

Compound 4, half-life: 24 h
The estimate for compound 4 lay 1.1-fold (0.04 log units) below the measured number; the measured number falls inside the stated range.
By their numbers in this assay, from the lowest: compound 3; then compounds 2 and 4 (each within the scatter of the next); then compound 1.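

In this assay, exchanging acetoxy directly for (pyridin-2-yl)sulfanyl on this saturated ring carbon gives a 3.8-fold higher number from compound 3 to compound 4 (0.58 log units; beyond the scatter) and confirms in a single swap that the attached group matters here. The two sulfur-linked aromatic rings cannot be told apart, at a 1.1-fold higher number from compound 2 to compound 4 (0.06 log units; within the scatter) despite their different ring hetero atom counts, so in this pair the half-life does not follow that difference. Even so, the new group does not restore the stability of the unsubstituted core, as a 4.4-fold lower number from compound 1 to compound 4 (0.65 log units; beyond the scatter) shows for this site.

Nothing available here explains why the half-life moves with these groups. Going by these compounds, it also remains open whether the sulfur link or the aromatic ring matters more, a question that methylsulfanyl at the same carbon could help to settle.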